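The source may hold more compounds than are shown below. What is called first, only, known or untested is meant among the compounds shown, and "the series" means these compounds.

Of the compounds shown here, three built on a shared core have been tested in a functional assay on T47D cells (Homo sapiens) for inhibition, read by sulforhodamine B assay, with a stated time of 48 h; on this read-out higher numbers stand for weaker inhibition of growth and lower numbers for stronger inhibition of growth. Compound 1 `COc1ccc(-c2cc(/C=C/C(=O)c3ccc(OC)c(OC)c3)[nH]n2)cc1` gives 1600 nM in this assay. Compound 2 `COc1cc(-c2cc(/C=C/C(=O)c3ccc(Cl)c(Cl)c3)[nH]n2)cc(OC)c1OC` gives 1660 nM in this assay, and compound 3 `COc1ccc(-c2cc(/C=C/C(=O)c3cc(OC)c(OC)c(OC)c3)[nH]n2)cc1OC` gives 1010 nM in this assay. Compound 2 carries the highest of the three numbers, yet its separation from compound 1 and from compound 3 lies within the scatter of repeated measurements, so the three cannot be ranked against one another on these figures.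

Compound 4 `COc1cc(-c2cc(/C=C/C(=O)c3ccc(F)c(F)c3)[nH]n2)cc(OC)c1OC` has not yet been measured. It differs from compound 2 in one place: 3,4-difluorophenyl in place of 3,4-dichlorophenyl on a carbonyl carbon. Among the compounds with values here, no pair of measured compounds shows this exchange, so there is no measured step to lean on, and the three measured values, which sit within scatter of each other, offer no sign that a change of this kind moves the number far. The step is therefore expected to be modest, a 1.3-fold higher number from compound 2 to compound 4 (0.12 log units; within the scatter), not beyond the scatter in either direction. Compound 4 is estimated to give 2200 nM in this assay, with a likely range from 900 nM to 5500 nM.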

Compound 4, concentration for 50% growth inhibition: 2450 nM
Estimate against measurement, compound 4: 1.1-fold (0.05 log units) below, and the stated range covers the measured number.
By their numbers in this assay, from the lowest: compounds 3, 1, 2 and 4 (each within the scatter of the next, the first and the last beyond it).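

In this assay, within the data shown here, the exchange of 3,4-dichlorophenyl for 3,4-difluorophenyl on a carbonyl carbon gives a 1.5-fold higher number from compound 2 to compound 4 (0.17 log units; within the scatter) and is the first step here between two compounds that differ in one place. At this position, then, the two pairs of halogen atoms cannot be told apart on this read-out, and swapping chlorine for fluorine leaves the number inside the noise of repeated measurements. No measurement shown here speaks to why the two groups read alike.

From the compounds shown here alone, it remains open whether a group of another kind on this carbonyl carbon, such as an aminophenyl or a carboxylic acid, would move the number beyond the scatter. Going by these compounds, it is also open whether the same halogen exchange would read alike with other groups on the rest of the shared core.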